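Adding a Chloro to an Ethoxy-Bearing Ligand

A few compounds are considered here, and "the series" means these few. Any claim that something is new, unique, unknown or untested is made for them only; others in the source may bear on it.

Three measured compounds share one core. Compound 1 `COc1cc(Cl)ccc1OCC1CN(Cc2ccc(Br)cc2)CCCO1` gives 2 nM in an assay on isolated protein with D(4) dopamine receptor (Homo sapiens) as the target; a higher number here means a weaker inhibitor, a lower number a stronger inhibitor; compound 2 `Cc1ncccc1OCC1CN(Cc2ccc(Cl)cc2)CCCO1` gives 83 nM in this assay; compound 3 `CCOc1ccccc1OCC1CN(Cc2ccc(Cl)cc2)CCCO1` gives 4.9 nM in this assay. Compound 3 thus holds the second highest of the three numbers, with compound 1 lying below it beyond the usual scatter and compound 2 lying well above it, also beyond the scatter.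

Compound 4 `CCOc1cc(Cl)ccc1OCC1CN(Cc2ccc(Cl)cc2)CCCO1` awaits measurement and differs from compound 3 by chloro in place of hydrogen on an aromatic carbon. Among the measured compounds shown here, no measured pair differs in this one place alone; the only guide is compound 1, which also carries a chloro and gives 2 nM, though compound 1 differs from compound 3 in other places as well. A modest lowering of the number is expected, a 2.0-fold lower number from compound 3 to compound 4 (0.29 log units; within the scatter). Compound 4 is estimated at 2.5 nM in this assay. Compound 4 is expected to fall between 0.9 nM and 7 nM.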

Compound 4, inhibition constant: 7 nM
Compound 4: the middle estimate sits 2.8-fold (0.45 log units) below what was measured, and the stated range covers the measured number.
By their numbers in this assay, from the lowest: compound 1; then compounds 3 and 4 (each within the scatter of the next); then compound 2.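

Chloro in place of hydrogen on this aromatic carbon, meta to an ethoxy group and para to a large group, gives a 1.4-fold higher number from compound 3 to compound 4 (0.15 log units; within the scatter) in this assay. Among the compounds shown here, this is the first step that isolates the position, and the chloro makes no difference beyond the scatter with the ethoxy group present. Nothing available accounts for this result. From the compounds shown here alone, it remains open whether fluoro, methoxy or an amine on this same carbon would give a step of similar size, and whether chloro here would do so with a group other than ethoxy on the ring.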